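The compounds below may be only part of what the source reports. "The series", "measured", "known", "first", "only" and "open" are said of these compounds alone.

Compound 1 (`CN1CCN(CNC(=O)c2cnccn2)CC1`) carries a methyl on an amine nitrogen in a ring. In a functional assay on Vero cells (Chlorocebus sabaeus) for cytotoxicity, read by MTT assay (on this read-out higher numbers stand for lower toxicity in this test and lower numbers for higher toxicity in this test), compound 1 is recorded as "not determined" (no result reported), so the series offers no number at this starting point. The nearest readings come from two other compounds that share its amide side chain. Compound 2 (`CCn1cc(C(=O)O)c(=O)c2cc(F)c(N3CCN(CNC(=O)c4cnccn4)CC3)cc21`) gives > 62.5 ug/mL, which is a limit of the assay. Compound 3 (`CCn1cc(C(=O)O)c(=O)c2cc(F)c(N3CCN(CNC(=O)c4cnccn4)CC3)c(F)c21`) gives > 62.5 ug/mL, which is also a limit. Fluoro in place of hydrogen on an aromatic carbon makes up the only measured change, a step that the two limits leave unreadable from compound 2 to compound 3. What the data offer is the limit of > 62.5 ug/mL in this assay, at which 2 of the 3 values shown sit.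

Compound 4 (`O=C(NCN1CCN(c2ccc(F)cc2)CC1)c1cnccn1`) has 4-fluorophenyl in place of methyl on an amine nitrogen in a ring, a change counted as 4-fluorophenyl in place of methyl on an amine nitrogen in a ring. Among the measured compounds shown here, no measured step covers this replacement. For the measured compounds named here, with a step that the two limits leave unreadable from compound 2 to compound 3 as the only guide, no definite step in either direction is expected in this assay, and a reading near that limit seems likely. Compound 4 is estimated at 70 ug/mL, with an expected range from 30 ug/mL to 150 ug/mL.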

Compound 4, half-maximal cytotoxic concentration: > 62.5 ug/mL
Compound 4: a limit, no number (the forecaster's own chance of this, stated with the estimate: 60%); the middle value does not contradict the limit.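

In this assay compound 4 gives > 62.5 ug/mL, which is a limit of the assay. Compound 1 offers no number to set against it, so no step can be read between compound 1 and compound 4. The compounds shown leave open where any actual half-maximal cytotoxic concentration lies, since the readings stop at one value: the limit of > 62.5 ug/mL in this assay, at which 3 of the 4 values shown sit.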